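This account rests on a few compounds, and the source may have more. Where it says the series, first, only, none or still open, it means among the compounds named here.

Working notes on the series in a functional assay on CHO cells with adenosine receptor A1 (Homo sapiens) as the target, read by cAMP accumulation and immunoassay, with a stated time of 6 min, tested at 1 uM; a lower number here means a stronger effect, a higher number a weaker effect of the compound at the concentration tested.

Compound 1 `CC(C)N1CCN(Cc2csc(N)c2C(=O)c2ccc(Cl)cc2)CC1` gives 7.3%. Compound 2 `Nc1scc(CN2CCN(c3ccc(Cl)cc3Cl)CC2)c1C(=O)c1ccc(Cl)cc1` gives -54%. Compound 3 `Nc1scc(CN2CCN(c3ccc([N+](=O)[O-])cc3)CC2)c1C(=O)c1ccc(Cl)cc1` gives -8.3%, which places compound 3 second highest of the three numbers: compound 1 sits above it and compound 2 well below it. The steps that change the group on the amine nitrogen in the ring are a number 61.3 percentage points lower from compound 1 to compound 2 (beyond the scatter), a number 15.6 percentage points lower from compound 1 to compound 3 (beyond the scatter) and a number 45.7 percentage points higher from compound 2 to compound 3 (beyond the scatter).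

Compound 4 `Nc1scc(CN2CCN(c3ccc(Cl)c(C(F)(F)F)c3)CC2)c1C(=O)c1ccc(Cl)cc1` has not yet been measured. Change from compound 3: 4-chloro-3-(trifluoromethyl)phenyl in place of 4-nitrophenyl on an amine nitrogen in a ring

The step that bears most directly on this is the aryl-for-aryl exchange on the same nitrogen, a number 45.7 percentage points higher from compound 2 to compound 3 (beyond the scatter), which was large; read in the opposite sense it shows that a halogenated phenyl on that nitrogen, in compound 2, gave a much lower number than 4-nitrophenyl in compound 3. The entering 4-chloro-3-(trifluoromethyl)phenyl is again a halogen-bearing phenyl, so the expectation is a downward step of some size rather than none. The step is expected to be a number 26.7 percentage points lower from compound 3 to compound 4 (beyond the scatter). Compound 4 is therefore estimated at -35%, with a range from -65% to 0%; the value awaits measurement.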

Compound 4, a percentage reported as activity, at one concentration (the size of the read-out at that concentration, not a potency): -47%
For compound 4 the middle estimate is 12 percentage points above the measured one; the measured number falls inside the stated range.
By their numbers in this assay, from the lowest: compounds 2 and 4 (each within the scatter of the next); then compound 3; then compound 1.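

In this assay the second halogen-bearing phenyl on the amine nitrogen in the ring gives a number 7 percentage points higher from compound 2 to compound 4 (within the scatter) and so is not separated from the first, which means that 4-chloro-3-(trifluoromethyl)phenyl and 2,4-dichlorophenyl cannot be told apart by this read-out. Exchanging 4-nitrophenyl gives a number 38.7 percentage points lower from compound 3 to compound 4 (beyond the scatter) and exchanging isopropyl gives a number 54.3 percentage points lower from compound 1 to compound 4 (beyond the scatter) so the low number of compound 2 is no longer a single case: among the four compounds, the two halogen-bearing phenyls form one group, apart from both 4-nitrophenyl and isopropyl. No measurement at hand explains why these groups separate in this way.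

The compounds shown leave open whether the chlorine or the trifluoromethyl group matters more, as an unsubstituted phenyl or a phenyl carrying only one chlorine or only one trifluoromethyl group would be needed to separate their contributions. On these data alone, it is also open whether a phenyl carrying a methoxy group or a nitrile, or a benzyl group on the same nitrogen, would join the halogen-bearing pair or stay nearer compound 3.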